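Removing one hydroxy from the 2,3-dihydroxyphenyl side

The source may report more compounds than this note shows. Statements on the series, on what has been measured and on what is new or still open speak of the compounds shown alone.

Compound 1 `O=C(/C=C/c1ccc(O)c(O)c1)CC(=O)/C=C/c1cccc(O)c1O`: 16000 nM
Compound 2 `O=C(/C=C/c1cccc(O)c1O)CC(=O)/C=C/c1cccc(O)c1O`: 39000 nM

In an ADME assay on PC-12 cells (Rattus norvegicus) for cytotoxicity, read by WST assay, with a stated time of 24 h (on this read-out higher numbers stand for lower toxicity in this test and lower numbers for higher toxicity in this test), compound 2 stands highest of the two measured compounds at 39000 nM. Compound 3 `O=C(/C=C/c1ccccc1O)CC(=O)/C=C/c1cccc(O)c1O` differs from compound 2 by hydrogen in place of hydroxy on an aromatic carbon, which reads as 2,3-dihydroxyphenyl to 2-hydroxyphenyl. Among the compounds with values here, the only measured step that bears on this is a 2.4-fold higher number from compound 1 to compound 2 (0.39 log units; beyond the scatter), a modest one. Within the data shown here, that step swaps one dihydroxyphenyl pattern for another, and no measured step removes a hydroxy. No step beyond the scatter is therefore expected. The expected step is a 1.1-fold higher number from compound 2 to compound 3 (0.03 log units; within the scatter). For compound 3 the estimate is 42000 nM, with an expected range of 17000 nM to 100000 nM.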

Compound 3, half-maximal cytotoxic concentration: 34000 nM
Beside the measured number, compound 3's estimate is 1.2-fold (0.09 log units) above it; the measured number falls inside the stated range.
By their numbers in this assay, from the lowest: compound 1; then compounds 3 and 2 (each within the scatter of the next).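

In this assay the change from 2,3-dihydroxyphenyl to 2-hydroxyphenyl gives a 1.1-fold lower number from compound 2 to compound 3 (0.06 log units; within the scatter) and so shows that this hydroxy can give way to hydrogen without a step beyond the scatter. The other comparison, a 2.1-fold higher number from compound 1 to compound 3 (0.33 log units; beyond the scatter), keeps compound 1 apart from compound 3 as it does from compound 2, so that gap holds with either side in place of 3,4-dihydroxyphenyl. Nothing measured here offers a reason for either step.

Open, from the compounds shown here alone, is whether a methoxy or an amine on that aromatic carbon would stay within the scatter of compound 2. Also open, going by these compounds, is what removing the remaining hydroxy of the 2-hydroxyphenyl group would do.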